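This account rests on a few compounds, and the source may have more. Where it says the series, first, only, none or still open, it means among the compounds named here.

Compound 1 `O=C(CCCCCCNC(=O)C(O)(O)C(F)(F)F)Nc1nccs1` gives 10800 nM in a functional assay on HCT-116 cells (Homo sapiens) for inhibition, read by colorimetric assay, with a stated time of 3 days; on this read-out higher numbers stand for weaker inhibition and lower numbers for stronger inhibition.
Compound 2 `O=C(CCCCCCNC(=O)C(O)(O)C(F)(F)F)Nc1ccc(F)cc1` gives 7570 nM in this assay.
Compound 3 `O=C(CCCCCCNC(=O)C(O)(O)C(F)(F)F)Nc1ccc(-c2ccccc2)cc1` gives 4730 nM in this assay.

Compound 2 stands second highest of the three numbers in this assay. The step of a 1.4-fold lower number from compound 1 to compound 2 (0.15 log units; within the scatter) and the step of a 1.6-fold lower number from compound 2 to compound 3 (0.20 log units; within the scatter) are both within the scatter, so the three measured compounds are not separated on this read-out. Compound 4 `O=C(CCCCCCNC(=O)C(O)(O)C(F)(F)F)Nc1ccccc1Br` is not yet measured; it differs from compound 2 by 2-bromophenyl in place of 4-fluorophenyl on an amide-type nitrogen. Both measured steps bear on it, since each changes the group on the amide-type nitrogen, and both were small. Going by the values given here, no measured step exchanges a 4-fluorophenyl for a 2-bromophenyl, so the direction is open. A step of a 1.1-fold higher number from compound 2 to compound 4 (0.02 log units; within the scatter) in this assay is therefore expected, nothing beyond the scatter. Compound 4 is estimated at 8000 nM, with a range of 3500 nM to 18000 nM.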

Compound 4, half-maximal inhibitory concentration: 14500 nM
The estimate for compound 4 lay 1.8-fold (0.26 log units) below the measured number; the range from low to high includes it.
By their numbers in this assay, from the lowest: compounds 3, 2, 1 and 4 (each within the scatter of the next, the first and the last beyond it).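

In this assay, a bromine-bearing aryl group on the amide-type nitrogen still gives no separation from either neighbour: a 1.9-fold higher number from compound 2 to compound 4 (0.28 log units; within the scatter) and a 1.3-fold higher number from compound 1 to compound 4 (0.13 log units; within the scatter). The series now spans a pair beyond the scatter, as compound 3 gives 4730 nM and compound 4 gives 14500 nM. No supporting data accompany these numbers to account for them.

As far as these compounds go, whether 4-bromophenyl on the same nitrogen would read with compound 2 or with compound 4 stays open. Also open, from the compounds shown here alone, is whether an amine or a carboxylic acid on that aryl group would move the number beyond the scatter.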